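A Benzyl to Isopropyl Swap on the Amide Nitrogen

The source may hold more compounds than are shown below. What is called first, only, known or untested is meant among the compounds shown, and "the series" means these compounds.

Compound 1 `COc1ccc(C(=O)/C=C/c2ccc(C(=O)NCc3ccccc3)cc2)c(O)c1` is the starting point. In an ADME assay on SH-SY5Y cells (Homo sapiens) for cytotoxicity, read by MTT assay, with a stated time of 48 h (on this read-out lower numbers stand for stronger inhibition and higher numbers for weaker inhibition), compound 1 gives only a limit of the assay, > 100000 nM. Compound 2 `CCOCCOc1cccc(/C=C/C(=O)c2ccc(OC)cc2O)c1` belongs to the same set. In this assay compound 2 also gives only a limit, > 100000 nM. Both readings sit at the limit of > 100000 nM in this assay, at which 2 of the 2 values shown sit, so compound 1 stands at the edge of what this assay reports, with no number to rank against. Compound 3 `COc1ccc(C(=O)/C=C/c2ccc(C(=O)NC(C)C)cc2)c(O)c1` is not yet measured. It differs from compound 1 by isopropyl in place of benzyl on an amide-type nitrogen. Going by the values given here, no measured step covers such a change, so no step beyond the scatter is expected, and another limit seems most likely. Compound 3 is therefore expected to give about 150000 nM, within 60000 nM to 400000 nM, an expected step that the limit leaves unreadable from compound 1 to compound 3.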

Compound 3, half-maximal inhibitory concentration: > 100000 nM
Compound 3: no number, only a limit (the forecaster's own chance of this, stated with the estimate: 80%); the middle value is on the limit's open side.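

In this assay compound 3 gives only a limit, > 100000 nM. Compound 1 also gives only a limit, so no step between compound 1 and compound 3 can be read: the limit of > 100000 nM in this assay, at which 3 of the 3 values shown sit.

The compounds shown leave open whether benzyl and isopropyl on the amide-type nitrogen differ at all, and where the true value of each compound lies.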